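A few compounds are considered here, and "the series" means these few. Any claim that something is new, unique, unknown or untested is made for them only; others in the source may bear on it.

- Compound 1 `NC(=O)c1ccc(N(Cc2ccc(C3CCCCC3)cn2)C(=O)[C@H]2CCN2S(=O)(=O)c2c(F)c(F)c(F)c(F)c2F)c(F)c1` | "not determined" (no result reported) 
- Compound 2 `CN(C)C(=O)c1ccc(N(Cc2ccc(C3CCCCC3)cn2)C(=O)[C@H]2CCN2S(=O)(=O)c2c(F)c(F)c(F)c(F)c2F)cc1O` | "not determined" (no result reported) 
- Compound 3 `O=C([C@H]1CCN1S(=O)(=O)c1c(F)c(F)c(F)c(F)c1F)N(Cc1ccc(C2CCCCC2)cn1)c1ccc2c(=O)[nH]ccc2c1` | 2200 nM 

The series was examined in a functional assay on MCF7 cells (Homo sapiens) for antiproliferative activity, with a stated time of 72 h; on this read-out lower numbers stand for an effect already at smaller amounts and higher numbers for an effect only at larger amounts of compound. Among the compounds with values here, compound 3 gives the only number in this set (2200 nM), so it can be ranked against no other compound, and compound 1 and compound 2 offer no reference point. Compound 4 `O=C1NC(=O)c2cc(N(Cc3ccc(C4CCCCC4)cn3)C(=O)[C@H]3CCN3S(=O)(=O)c3c(F)c(F)c(F)c(F)c3F)ccc21` is still unmeasured. It keeps the shared core and changes only the group on an amide-type nitrogen: a group of 11 heavy atoms (8 carbon, 1 nitrogen, 2 oxygen; one five-membered non-aromatic ring with 1 hetero atom, one six-membered aromatic ring of carbon only) in place of a group of 11 heavy atoms (9 carbon, 1 nitrogen, 1 oxygen; one six-membered aromatic ring of carbon only, one six-membered aromatic ring with 1 hetero atom), on an amide-type nitrogen. The replacement group keeps one six-membered aromatic ring of carbon only, but a five-membered non-aromatic ring with 1 hetero atom takes the place of the six-membered aromatic ring with 1 hetero atom. Within the data shown here, no step between measured compounds is available to show how much such a change matters, so the expectation rests on compound 3 (2200 nM) and the structural change alone. No shift beyond the usual scatter is expected, with a slight lean towards a higher number, and the estimated step is a 1.4-fold higher number from compound 3 to compound 4 (0.13 log units; within the scatter) in this assay as a working figure. Compound 4 is estimated at 3000 nM with an expected range from 1000 nM to 9000 nM in this assay when measured.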

Compound 4, half-maximal effective concentration: 7000 nM
Compound 4: the middle estimate sits 2.3-fold (0.37 log units) below what was measured; low and high end bracket the measured number.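

In this assay, the amide-type nitrogen now has its first measured step: a 3.2-fold higher number from compound 3 to compound 4 (0.50 log units; beyond the scatter). The place therefore responds to the exchange of one group for another, even though both groups have 11 heavy atoms, no net charge and a six-membered aromatic ring of carbon only. Nothing shown gives a measured reason for the difference.

Within the data shown here, with only this single step, the effect of the five-membered non-aromatic ring with 1 hetero atom cannot be separated from that of the second double bond outside aromatic rings, and steps involving compound 1 or compound 2 cannot be read. The compounds shown also leave open how a group carrying a carboxylic acid or an amine would behave on this nitrogen.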